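Swapping a Bromophenyl for a Thiophenyl Group

This account rests on a few compounds, and the source may have more. Where it says the series, first, only, none or still open, it means among the compounds named here.

Compound 1 `COc1cc(-c2cc(-c3ccc(N)cc3)nc(-c3ccccc3)n2)cc(OC)c1OC` gives 1010 nM in a functional assay on MDA-MB-231 cells (Homo sapiens) for inhibition, read by MTT assay, with a stated time of 48 h; on this read-out higher numbers stand for weaker inhibition and lower numbers for stronger inhibition.
Compound 2 `COc1cc(-c2cc(-c3ccc(Br)cc3)nc(-c3ccccc3)n2)cc(OC)c1OC` gives > 25000 nM in this assay, which is a limit of the assay and not a number.
Compound 3 `COc1cc(-c2cc(-c3ccccc3)nc(-c3ccccc3)n2)cc(OC)c1OC` gives 5870 nM in this assay.

Compound 2 stands at the weak end of these three: its reading is only a limit, (the limit of > 25000 nM in this assay, at which 1 of the 3 values shown sits), so it is known to sit at or beyond that edge. Against compound 1 the change is an at least 24-fold higher number from compound 1 to compound 2 (1.39 log units; beyond the scatter), and against compound 3 it is an at least 4.2-fold lower number from compound 2 to compound 3 (0.62 log units; beyond the scatter), so shedding the bromo already moves the number down.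

Compound 4 `COc1cc(-c2cc(-c3cccs3)nc(-c3ccccc3)n2)cc(OC)c1OC` differs from compound 2 as follows: thiophen-2-yl in place of 4-bromophenyl on an aromatic carbon. Within the data shown here, the step most closely related is the one from compound 2 to compound 3, where taking the bromo away gave a lower number; here the whole 4-bromophenyl leaves and a smaller five-membered ring with one sulfur enters. A lowering of the number is therefore expected in this assay, but its size is uncertain because compound 2 gives only a limit, (the limit of > 25000 nM in this assay, at which 1 of the 3 values shown sits). Compound 4 is estimated at 7000 nM, with a range from 2000 nM to 25000 nM, which amounts to an expected step of an at least 3.5-fold lower number from compound 2 to compound 4 (0.55 log units; beyond the scatter).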

Compound 4, half-maximal inhibitory concentration: 5110 nM
Compound 4: the middle estimate sits 1.4-fold (0.14 log units) above what was measured; the measured number falls inside the stated range.
By their numbers in this assay, from the lowest: compound 1; then compounds 4 and 3 (each within the scatter of the next). At a limit, above all of these: compound 2.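

In this assay thiophen-2-yl at this position moves the reading clear of the weak end, with an at least 4.8-fold lower number from compound 2 to compound 4 (0.68 log units; beyond the scatter), but that step starts from compound 2, whose reading is a limit and not a number: the limit of > 25000 nM in this assay, at which 1 of the 4 values shown sits. What is new is that a ring of a different size and with a sulfur atom reads the same as the phenyl of compound 3 (a 1.1-fold lower number from compound 3 to compound 4 (0.06 log units; within the scatter)), so in these two compounds the exchange of one unsubstituted aromatic ring for the other makes no difference that can be told apart. Neither ring matches the 4-aminophenyl of compound 1, with a 5.1-fold higher number from compound 1 to compound 4 (0.70 log units; beyond the scatter), so among the compounds shown only the amino-bearing ring stands out.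

The compounds shown leave open whether an amino group carried on the thiophen-2-yl would bring the same gain as on the phenyl. They also leave open whether a furan-2-yl or a pyridin-3-yl group in this place would read like thiophen-2-yl.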